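Moving the hydroxyl: 4-hydroxyphenyl to 3-hydroxyphenyl

A few compounds are considered here, and "the series" means these few. Any claim that something is new, unique, unknown or untested is made for them only; others in the source may bear on it.

Values measured in a functional assay on HCT-116 cells (Homo sapiens) for antiproliferative activity, with a stated time of 72 h (on this read-out lower numbers stand for stronger inhibition and higher numbers for weaker inhibition), are as follows.
- Compound 1 (`COc1ccccc1/C=C/c1nc(Nc2ccccc2Cl)c2ccccc2n1`): 16100 nM
- Compound 2 (`COc1ccccc1/C=C/c1nc(Nc2ccc(O)cc2)c2ccccc2n1`): 17900 nM
- Compound 3 (`COc1cccc(/C=C/c2nc3ccccc3c(=O)[nH]2)c1`): > 25000 nM (a limit, not a number)

Compound 2 cannot be told apart from compound 1, since the measured step is a 1.1-fold higher number from compound 1 to compound 2 (0.05 log units; within the scatter). The reading for compound 3 is only a limit.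

The next compound, compound 4 (`COc1ccccc1/C=C/c1nc(Nc2cccc(O)c2)c2ccccc2n1`), has the same atoms as compound 2, joined differently: 3-hydroxyphenyl in place of 4-hydroxyphenyl on a nitrogen on an aromatic ring.

Going by the values given here, only the step from compound 1 to compound 2 bears on this change. There, 4-hydroxyphenyl replaced 2-chlorophenyl on the same nitrogen, and the number stayed within the scatter. One step is thin evidence, but it gives no reason to expect a change beyond the scatter in this assay. The estimated step is a 1.1-fold lower number from compound 2 to compound 4 (0.05 log units; within the scatter). Compound 4 is expected at 16000 nM, with an estimated range from 8000 nM to 25000 nM.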

Compound 4, half-maximal inhibitory concentration: 16400 nM
For compound 4 the middle estimate is 1.0-fold (0.01 log units) below the measured one, within the range that was stated.
By their numbers in this assay, from the lowest: compounds 1, 4 and 2 (each within the scatter of the next). At a limit, above all of these: compound 3.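

In this assay, moving the hydroxyl on the ring gives a 1.1-fold lower number from compound 2 to compound 4 (0.04 log units; within the scatter), so the 4-hydroxyphenyl and 3-hydroxyphenyl groups on this nitrogen cannot be told apart. Going by these compounds alone, the earlier compounds showed only that one hydroxyl-bearing group could replace 2-chlorophenyl without a readable change, and the second such replacement gives a 1.0-fold higher number from compound 1 to compound 4 (0.01 log units; within the scatter), so all three groups on this nitrogen now read alike. Nothing shown here explains why these groups read alike.

As far as these compounds go, it remains open whether this sameness would hold for a group of another kind on the ring attached to this nitrogen, such as an amine or a carboxylic acid. From the compounds shown here alone, it is also open whether a change elsewhere on the shared core would move the number beyond the scatter.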